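Adding chloro to the aryl ring of compound 2

The source may hold more compounds than are shown below. What is called first, only, known or untested is meant among the compounds shown, and "the series" means these compounds.

Compound 1 `Nc1nc(N)nc(-c2cccc(F)c2)n1` and compound 2 `Nc1nc(N)nc(-c2cccc(C(F)(F)F)c2)n1` differ only in the group carried on the aromatic carbon. In a functional assay on the whole organism with Rattus norvegicus as the target, at a dose of 20 mg/kg by the intraperitoneal route (on this read-out lower numbers stand for less inhibition and higher numbers for more inhibition at the one dose given (going by the name of the read-out)), compound 1 gives 70%, and compound 2 gives 81%. Among the measured compounds shown here, the single measured step, a number 11 percentage points higher from compound 1 to compound 2 (beyond the scatter), went with trifluoromethyl in place of fluoro on an aromatic carbon. Compound 2 thus stands highest of the two numbers, with compound 1 the nearest at a lower value beyond the scatter.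

Compound 3 `Nc1nc(N)nc(-c2cc(C(F)(F)F)ccc2Cl)n1` keeps the trifluoromethyl and adds a further group: chloro in place of hydrogen on an aromatic carbon. For the measured compounds named here, no measured step concerns chloro entering on an aromatic carbon, so the step from compound 1 to compound 2 is only a loose guide that a change on this ring moved this assay modestly. The expected step is a number 3 percentage points lower from compound 2 to compound 3 (within the scatter), within or close to the scatter. Compound 3 is therefore expected to give 78% in this assay, with a range from 55% to 95%.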

Compound 3, a percentage reported as inhibition, in the whole organism at one dose (the size of the read-out at that dose, not a potency): 51%
For compound 3 the middle estimate is 27 percentage points above the measured one; the whole stated range lies above it.
By their numbers in this assay, from the lowest: compound 3; then compound 1; then compound 2.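

In this assay, chloro in place of hydrogen on an aromatic carbon, ortho to a group of 8 heavy atoms and para to a trifluoromethyl group, goes with a number 30 percentage points lower from compound 2 to compound 3 (beyond the scatter) in the read-out. This position is therefore not indifferent: keeping the trifluoromethyl does not keep the number of compound 2 once chloro enters here. With a single step at this position, the result describes this one change and sets no trend. Nothing available bears on the reason for this fall.

Going by these compounds, it remains open whether methyl, methoxy or an amine at the same position would go with a similar fall. Also open, on these data alone, is whether chloro here would go with a comparable step when fluoro replaces the trifluoromethyl, as in compound 1.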